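Notes on the series: from compound 2 to compound 3

A few compounds are considered here, and "the series" means these few. Any claim that something is new, unique, unknown or untested is made for them only; others in the source may bear on it.

Among the measured compounds shown here, in a functional assay on MCF7 cells (Homo sapiens) for inhibition, read by MTT assay (on this read-out lower numbers stand for stronger inhibition and higher numbers for weaker inhibition), compound 1 (`CCc1ccc(C(=O)Nc2ccc(Nc3ncnc4cc(OC)c(OC)cc34)cc2)cc1`) gives 65000 nM and compound 2 (`COc1cc2ncnc(Nc3ccc(NC(=O)c4ccccc4F)cc3)c2cc1OC`) gives 11000 nM, the lower of the two numbers so far. Compound 3 (`COc1cc2ncnc(Nc3ccc(NC(=O)c4cccc(Cl)c4)cc3)c2cc1OC`) keeps the shared core and changes only the group on the carbonyl carbon: 3-chlorophenyl in place of 2-fluorophenyl on a carbonyl carbon. In words, 3-chlorophenyl stands in place of 2-fluorophenyl on a carbonyl carbon. For the measured compounds named here, one measured step bears on this place: a 5.9-fold lower number from compound 1 to compound 2 (0.77 log units; beyond the scatter), modest but beyond the scatter. That step involved 4-ethylphenyl, so it suggests a likely size and gives no firm direction. A step of similar or smaller size is expected in this assay, with a slight lean towards a higher number. The estimate amounts to a 1.4-fold higher number from compound 2 to compound 3 (0.13 log units; within the scatter). The expected value for compound 3 is 15000 nM, with an estimated range from 4000 nM to 50000 nM.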

Compound 3, half-maximal inhibitory concentration: 18000 nM
For compound 3 the middle estimate is 1.2-fold (0.08 log units) below the measured one; the measured number falls inside the stated range.
By their numbers in this assay, from the lowest: compounds 2 and 3 (each within the scatter of the next); then compound 1.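

In this assay, 3-chlorophenyl in place of 2-fluorophenyl on a carbonyl carbon gives a 1.6-fold higher number from compound 2 to compound 3 (0.21 log units; within the scatter) and so does not separate these two groups at this position. Compared with 4-ethylphenyl, 3-chlorophenyl gives a 3.6-fold lower number from compound 1 to compound 3 (0.56 log units; beyond the scatter) and thus adds a second step beyond the scatter, so among these three compounds the one bearing 4-ethylphenyl carries the highest number, with no compound going against that order. No measurement available here offers an explanation for these numbers.

The compounds shown leave open whether the halogen or its placement on the ring matters, since 2-fluorophenyl and 3-chlorophenyl differ in both, and 3-fluorophenyl or 2-chlorophenyl would separate the two. As far as these compounds go, how an amine, a carboxylic acid or a longer chain would read at this position also remains open.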